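A few compounds are considered here, and "the series" means these few. Any claim that something is new, unique, unknown or untested is made for them only; others in the source may bear on it.

Working notes on the series.

Within the data shown here, compound 1 `CCC(c1ccc(-c2cscc2C)cc1)n1ccnc1` stands highest of the two numbers so far: in an assay for inhibition of steroid 17-alpha-hydroxylase/17,20 lyase (Homo sapiens), using NADPH, tested at 2 uM (on this read-out higher numbers stand for a stronger effect at the one concentration tested and lower numbers for a weaker effect), compound 1 gives 84%. Compound 2 `Cc1cscc1-c1ccc(Cn2ccnc2)cc1` is its nearest neighbour, and in this assay compound 2 gives 27%. Among the measured compounds shown here, the one measured step, a number 57 percentage points lower from compound 1 to compound 2 (beyond the scatter), concerns hydrogen in place of ethyl on a saturated chain carbon bound to an aromatic carbon and an aromatic nitrogen.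

Compound 3 `CCC(c1ccc(-c2ccsc2)cc1)n1ccnc1` differs from compound 1 by hydrogen in place of methyl on an aromatic carbon. For the measured compounds named here, no measured step touches the five-membered aromatic ring with 1 sulfur, so the step from compound 1 to compound 2 does not bear on this change and gives no guide to its size. With compound 1 already near the top of the read-out, a change beyond the scatter, if any, is expected to run downward rather than upward in this assay. Compound 3 is therefore expected to give 70%, within 45% to 90%, an expected step of a number 14 percentage points lower from compound 1 to compound 3 (beyond the scatter).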

Compound 3, a percentage reported as inhibition, at one concentration (the size of the read-out at that concentration, not a potency): 83%
Compound 3: middle estimate off by 13 percentage points, on the low side; low and high end bracket the measured number.
By their numbers in this assay, from the lowest: compound 2; then compounds 3 and 1 (each within the scatter of the next).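

In this assay, the change from 4-methylthiophen-3-yl to thiophen-3-yl gives a number 1 percentage points lower from compound 1 to compound 3 (within the scatter), so at the one concentration tested this read-out does not separate methyl from hydrogen on this aromatic carbon of the sulfur ring. This is the first measured step at this position, and of the two steps now listed only a number 57 percentage points lower from compound 1 to compound 2 (beyond the scatter) lies beyond the scatter. No measurement in hand accounts for the methyl step or for the contrast between the two steps.

The compounds shown leave open whether an amine or a carboxylic acid on this aromatic carbon would also stay within the scatter of compound 1, and whether the ethyl step would carry over to the thiophen-3-yl compound. Going by these compounds, the read-out gives the size of the effect at one concentration only, so whether compound 1 and compound 3 would show a stronger or weaker effect relative to each other at any other concentration also stays open.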